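Benzyl in Place of Thiophen-2-yl on a Shared Core

A few compounds are considered here, and "the series" means these few. Any claim that something is new, unique, unknown or untested is made for them only; others in the source may bear on it.

Compound 1 `Nc1cccc(-c2cn3nc(-c4cccs4)sc3n2)c1` carries a free amino group and a thiophen-2-yl group on its shared core. In a functional assay on HeLa cells (Homo sapiens) for inhibition, read by cell counting, with a stated time of 4 days (a higher number here means a weaker inhibitor, a lower number a stronger inhibitor), compound 1 gives only a limit of the assay, > 250000 nM, so no number is known for it. Compound 2 `C=C(Br)C(=O)Nc1cccc(-c2cn3nc(-c4ccc(OCC)cc4)sc3n2)c1` is the other measured compound, with an amide on the amino nitrogen and a different aryl group on the core; in this assay compound 2 gives 1100 nM. The two values show compound 2 as a measurable inhibitor while compound 1 sits at the limit (the limit of > 250000 nM in this assay, at which 1 of the 2 values shown sits). For the measured compounds named here, no step between compounds differing in one place is available. Compound 3 `Nc1cccc(-c2cn3nc(Cc4ccccc4)sc3n2)c1` is not yet measured and differs from compound 1 by benzyl in place of thiophen-2-yl on an aromatic carbon. The free amino group stays. The step from compound 1 to compound 3 is expected to be none beyond the scatter, so compound 3 is expected to give 250000 nM, within 60000 nM to 1000000 nM, with the step of a number no higher from compound 1 to compound 3 (the limit leaves the size open).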

Compound 3, half-maximal inhibitory concentration: 24000 nM
The estimate for compound 3 lay 10-fold (1.02 log units) above the measured number, outside the stated range (below it).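

This aromatic carbon, next to the ring sulfur, is a position where the group matters: with the free amino group kept, benzyl in place of thiophen-2-yl gives an at least 10-fold lower number from compound 1 to compound 3 (1.01 log units; beyond the scatter) in this assay. A measurable number therefore does not depend on an amide on the amino nitrogen, since compound 3 keeps the free amine and gives 24000 nM. Compound 1 has only a limit, so the size of this step is a bound and not an exact figure: the limit of > 250000 nM in this assay, at which 1 of the 3 values shown sits.

The compounds shown leave open whether the change depends on the six-membered ring itself or on the single carbon joining it to the core; a phenyl group set directly on the core, or a longer chain such as 2-phenylethyl, would separate the two. They also leave open how a bromoacrylamide on the amino nitrogen would act together with benzyl.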